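Benzyl halogen and position swap on the shared core

This account rests on a few compounds, and the source may have more. Where it says the series, first, only, none or still open, it means among the compounds named here.

Going by the values given here, in an assay on isolated protein for inhibition of serine/threonine-protein kinase PAK 4 (Homo sapiens), read by HTRF, with a stated time of 60 min (on this read-out higher numbers stand for weaker inhibition and lower numbers for stronger inhibition), compound 2 `Cc1cc(Nc2nc(NCc3ccccc3Br)nc3[nH]ncc23)n[nH]1` gives 1090 nM; compound 1 `Cc1cc(Nc2nc(NC3CCNC3)nc3[nH]ncc23)n[nH]1` gives 1050 nM, and the two sit within the scatter of each other, the only measured step being a 1.0-fold higher number from compound 1 to compound 2 (0.02 log units; within the scatter). Compound 3 `Cc1cc(Nc2nc(NCc3cccc(Cl)c3)nc3[nH]ncc23)n[nH]1` differs from compound 2 by 3-chlorophenyl in place of 2-bromophenyl on a saturated chain carbon bound to a nitrogen on an aromatic ring. Among the compounds with values here, that single measured step replaces the whole group on the ring nitrogen and says nothing about a halogen or its placement within a benzyl; no measured step bears on this change. No step beyond the scatter is therefore expected in this assay, and compound 3 is estimated at 1000 nM (range 400 nM to 2500 nM), an expected 1.1-fold lower number from compound 2 to compound 3 (0.04 log units; within the scatter).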

Compound 3, half-maximal inhibitory concentration: 611 nM
Compound 3: the middle estimate sits 1.6-fold (0.21 log units) above what was measured; low and high end bracket the measured number.
By their numbers in this assay, from the lowest: compounds 3, 1 and 2 (each within the scatter of the next).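

In this assay, 3-chlorophenyl in place of 2-bromophenyl gives a 1.8-fold lower number from compound 2 to compound 3 (0.25 log units; within the scatter) and stays on the same footing as the earlier pair, so this halogen and placement swap on the benzyl does not separate the compounds. Against the shared core carrying pyrrolidin-3-yl, 3-chlorobenzyl gives a 1.7-fold lower number from compound 1 to compound 3 (0.24 log units; within the scatter) and likewise leaves the group on the ring nitrogen undistinguished. No measurement at hand accounts for these numbers.

Halogen identity and placement change together here, so their separate contributions remain open. Also open, from the compounds shown here alone, is how a plain benzyl, or a benzyl carrying an amine or a carboxylic acid, would read in this position.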